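Trifluoromethyl in Place of Bromo on an Inactive Scaffold

This account rests on a few compounds, and the source may have more. Where it says the series, first, only, none or still open, it means among the compounds named here.

Compound 1 `C=C1C[C@]23C[C@@]1(O)CC[C@H]2c1ccc(OS(=O)(=O)c2ccc(C)cc2)c(C)c1[C@@H]3Cn1cc(-c2ccc(Br)cc2)nn1` was examined in a functional assay on A549 cells (Homo sapiens) for cytotoxicity, read by MTT assay, with a stated time of 4 days; on this read-out higher numbers stand for weaker inhibition and lower numbers for stronger inhibition. In this assay compound 1 reaches only a limit, > 20000 nM, and not a number (the limit of > 20000 nM in this assay, at which 1 of the 2 values shown sits). Compound 2 `C=C1C(=O)[C@]23C[C@@]1(O)CC[C@H]2c1ccc(O)c(C)c1[C@@H]3Cn1cc(-c2ccc(Br)cc2)nn1` differs from compound 1 in several places. In this assay compound 2 gives 1140 nM. Taken together, the two values show compound 2 as an active compound and compound 1 as one without a measurable result; no single step connects them.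

Compound 3 `C=C1C[C@]23C[C@@]1(O)CC[C@H]2c1ccc(OS(=O)(=O)c2ccc(C)cc2)c(C)c1[C@@H]3Cn1cc(-c2ccc(C(F)(F)F)cc2)nn1` has not yet been measured. It differs from compound 1 in one place: trifluoromethyl in place of bromo on an aromatic carbon.

Since compound 1 stands at the limit of this assay, the direction and size of the change from compound 1 to compound 3 cannot be read from a measured number. With the shared core of compound 1 otherwise unchanged, the account expects no step beyond the scatter, that is a number no higher from compound 1 to compound 3 (the limit leaves the size open). For compound 3 the estimate in this assay is 20000 nM, with a range from 8000 nM to 50000 nM, and it is expected that the assay most likely again reports only a limit.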

Compound 3, half-maximal inhibitory concentration: > 20000 nM
Compound 3 was reported as a limit (the forecaster's own chance of this, stated with the estimate: 70%); the middle value sits exactly at the limit.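

In this assay compound 3 gives > 20000 nM, which is a limit of the assay and not a number. Compound 1 stands at the same limit, so no step from compound 1 to compound 3 can be read: the limit of > 20000 nM in this assay, at which 2 of the 3 values shown sit.

The compounds shown leave open whether trifluoromethyl in place of bromo changes the result where a compound gives a measurable value, as compound 2 does.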